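The source may hold more compounds than are shown below. What is called first, only, known or untested is meant among the compounds shown, and "the series" means these compounds.

Measured so far in a functional assay on NCI-H460 cells (Homo sapiens) for cytotoxicity, read by MTT assay, with a stated time of 72 h; a lower number here means a stronger inhibitor, a higher number a weaker inhibitor:

- compound 1, `CN(C)CCn1cnnc1-c1cc(Oc2ccc(NC(=O)N/N=C/c3ccccc3)cc2F)ccn1`, gives 1780 nM
- compound 2, `CN(C)CCn1cnnc1-c1cc(Oc2ccc(NC(=O)N/N=C/c3ccc(F)cc3)cc2F)ccn1`, gives 1980 nM
- compound 3, `CN(C)CCn1cnnc1-c1cc(Oc2ccc(NC(=O)N/N=C/c3ccc(O)cc3)cc2F)ccn1`, gives 1780 nM

All three compounds share one core and differ only in a single group on the outer aromatic ring. From compound 1 to compound 2 the change is fluoro in place of hydrogen on an aromatic carbon, and in this assay this gave a 1.1-fold higher number from compound 1 to compound 2 (0.05 log units; within the scatter). Compound 3 carries a hydroxy group instead, and the step is no change at the digits printed from compound 1 to compound 3 (within the scatter). Between compound 2 and compound 3 the gap is a 1.1-fold lower number from compound 2 to compound 3 (0.05 log units; within the scatter). The three numbers therefore sit within the scatter of one another, and none of them can be called stronger or weaker than the rest.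

Compound 4, `CN(C)CCn1cnnc1-c1cc(Oc2ccc(NC(=O)N/N=C/c3ccc(O)c(F)c3)cc2F)ccn1`, has not yet been measured. It stands to compound 3 as compound 2 stands to compound 1: the change is fluoro in place of hydrogen on an aromatic carbon. The two cores differ by hydroxy in place of hydrogen on an aromatic carbon. The surroundings of the new group are not identical, though: in compound 2 the fluoro sits para to a large group, whereas in compound 4 it sits ortho to a hydroxy group and meta to a large group, so this is the same kind of change rather than the same change. For the measured compounds named here, the one measured example of it gave a 1.1-fold higher number from compound 1 to compound 2 (0.05 log units; within the scatter). On that basis the step is expected to be a 1.1-fold higher number from compound 3 to compound 4 (0.03 log units; within the scatter). Compound 4 is estimated to give 1900 nM in this assay, with a likely range from 1000 nM to 3600 nM.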

Compound 4, half-maximal inhibitory concentration: 2620 nM
Beside the measured number, compound 4's estimate is 1.4-fold (0.14 log units) below it, within the range that was stated.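

In this assay, fluoro in place of hydrogen on the core of compound 3 gave a 1.5-fold higher number from compound 3 to compound 4 (0.17 log units; within the scatter), and the two wider comparisons read a 1.3-fold higher number from compound 2 to compound 4 (0.12 log units; within the scatter) and a 1.5-fold higher number from compound 1 to compound 4 (0.17 log units; within the scatter). Set beside the earlier case, the change carries from one core to the other with no difference that these measurements can detect: the same change on two cores in this assay, a 1.1-fold higher number (0.05 log units; within the scatter) from compound 1 to compound 2 and a 1.5-fold higher number (0.17 log units; within the scatter) from compound 3 to compound 4, 1.3-fold (0.12 log units) apart, within the scatter of two such steps. For the compounds shown here, this does not show that the two steps are truly equal or that the change would behave the same way on other cores: the comparison rests on only two pairs, and only in compound 4 does the fluoro sit ortho to a hydroxy group.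

The compounds shown carry only hydrogen, fluoro and hydroxy on the outer aromatic ring, and their numbers all lie within the scatter of one another, so it remains open whether a different group there, such as an amine or a carboxylic acid, would give a step beyond the scatter. From the compounds shown here alone, it also remains open whether the fluoro step would stay this small with a methoxy group or an amine in place of the hydroxy group.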